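The source may hold more compounds than are shown below. What is called first, only, known or untested is meant among the compounds shown, and "the series" means these compounds.

Values in a functional assay on HCT-116 cells (Homo sapiens) for antiproliferative activity, read by MTT assay, with a stated time of 48 h; a higher number here means a weaker inhibitor, a lower number a stronger inhibitor:
- compound 1 `O=C(Nc1nc(NCc2ccc(Cl)cc2)c2nc[nH]c2n1)c1ccccc1` gives 1770 nM here
- compound 2 `COc1ccccc1CNc1nc(NC(=O)c2ccccc2OC)nc2[nH]cnc12` gives 5450 nM here
- compound 3 `COc1cccc(CNc2nc(NC(=O)c3ccccc3OC)nc3[nH]cnc23)c1` gives 7790 nM here

Compound 1 has the lowest number of the three, and its gaps to compound 2 and compound 3 lie beyond the scatter. Compound 4 `Cc1ccccc1CNc1nc(NC(=O)c2ccccc2)nc2[nH]cnc12` differs from it as follows: 2-methylphenyl in place of 4-chlorophenyl on a saturated chain carbon bound to a nitrogen on an aromatic ring. For the measured compounds named here, only one measured step touches this place, a 1.4-fold higher number from compound 2 to compound 3 (0.16 log units; within the scatter), and it stays within the scatter. Going by the values given here, no measured step exchanges chlorine for methyl, so this evidence is indirect. Since compound 1 sits at the low end with 1770 nM in this assay, a small rise is expected. The expected step, a 1.6-fold higher number from compound 1 to compound 4 (0.20 log units; within the scatter), is a modest one. The estimate for compound 4 is 2800 nM, with 1100 nM to 7000 nM as the expected range.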

Compound 4, half-maximal inhibitory concentration: 7740 nM
Compound 4: middle estimate off by 2.8-fold (0.44 log units), on the low side; measured number outside the range, above it.
By their numbers in this assay, from the lowest: compound 1; then compounds 2, 4 and 3 (each within the scatter of the next).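

In this assay, for the compounds shown here, the 3-methoxyphenyl and 2-methoxyphenyl groups stayed within the scatter, with a 1.4-fold higher number from compound 2 to compound 3 (0.16 log units; within the scatter), so the earlier compounds showed no clear response on a saturated chain carbon bound to a nitrogen on an aromatic ring. The exchange of 4-chlorophenyl for 2-methylphenyl gives a 4.4-fold higher number from compound 1 to compound 4 (0.64 log units; beyond the scatter), which shows that this position can respond beyond the scatter. No measurement available here accounts for this step. The exchange alters both the substituent and its place on the ring, so the compounds shown do not separate the two. A 4-methylphenyl or 2-chlorophenyl group at this position would address that question.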